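From Oxan-4-yl to Two Four-Membered Rings

The compounds below may be only part of what the source reports. "The series", "measured", "known", "first", "only" and "open" are said of these compounds alone.

In an ADME assay on microsomes from liver (Rattus norvegicus) for metabolic stability, using NADPH, with a stated time of 10 min (a higher number here means that more of the compound is left, a lower number that less of the compound is left), three compounds sharing one core have been measured. Compound 1 `CN(C)CCCCN(C[C@H]1Cc2ncccc2CN1)[C@H]1CCCc2cccnc21`, with methyl on the amine nitrogen, gives 27%. Compound 2 `CN(CCCCN(C[C@H]1Cc2ncccc2CN1)[C@H]1CCCc2cccnc21)C1CCC(F)(F)CC1`, with 4,4-difluorocyclohexyl in that place, gives 8%. Compound 3 `CN(CCCCN(C[C@H]1Cc2ncccc2CN1)[C@H]1CCCc2cccnc21)C1CCOCC1`, with oxan-4-yl there, gives 64%, the highest of the three numbers.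

Compound 4 `c1cnc2c(c1)CN[C@@H](CN(CCCCN(C1COC1)C1COC1)[C@H]1CCCc3cccnc31)C2` departs from compound 3 in this way: a group of 9 heavy atoms (6 carbon, 1 nitrogen, 2 oxygen; 2 four-membered non-aromatic rings with 1 hetero atom each) in place of a group of 8 heavy atoms (6 carbon, 1 nitrogen, 1 oxygen; one six-membered non-aromatic ring with 1 hetero atom), on a saturated chain carbon, four bonds along the chain from an amine nitrogen. Going by the values given here, no measured compound carries the entering group, so the evidence is indirect. The swap of methyl for 4,4-difluorocyclohexyl gave a modest fall, a number 19 percentage points lower from compound 1 to compound 2 (beyond the scatter). The swap of methyl for oxan-4-yl gave a large rise, a number 37 percentage points higher from compound 1 to compound 3 (beyond the scatter), and the swap of 4,4-difluorocyclohexyl for oxan-4-yl gave another, a number 56 percentage points higher from compound 2 to compound 3 (beyond the scatter). Among the compounds with values here, compound 3 is the only measured compound with an oxygen in its ring, and the entering group also holds oxygen in its rings. Compound 3, at 64%, is therefore taken as the best guide, although a single compound cannot establish a pattern. No step beyond the scatter is expected, and the estimated step is a number 4 percentage points higher from compound 3 to compound 4 (within the scatter). For compound 4 the estimated value is 68%, with an expected range from 45% to 88%.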

Compound 4, percent of the compound remaining: 72%
Compound 4: middle estimate off by 4 percentage points, on the low side, within the range that was stated.
By their numbers in this assay, from the lowest: compound 2; then compound 1; then compounds 3 and 4 (each within the scatter of the next).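

In this assay, the step with two four-membered non-aromatic rings in place of methyl(oxan-4-yl)amino, a number 8 percentage points higher from compound 3 to compound 4 (within the scatter), shows that the position accepts this larger change of ring size and ring count without a step that can be told from the scatter. The entering group also stands well clear of the two groups without ring oxygen, with a number 64 percentage points higher from compound 2 to compound 4 (beyond the scatter) and a number 45 percentage points higher from compound 1 to compound 4 (beyond the scatter), so the link between ring oxygen and a higher number now rests on two compounds rather than one, and none of the four compounds goes against it. The data shown offer no measurement that accounts for these differences among the groups at this position.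

The compounds shown leave open whether both four-membered rings are needed, since no compound has an amine nitrogen carrying methyl and just one such ring. They also leave open whether the oxygen must sit in a ring at all, which a 2-methoxyethyl group on that nitrogen would test, and whether a piperidin-4-yl group, with ring nitrogen instead of oxygen, would behave like oxan-4-yl.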